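The source may report more compounds than this note shows. Statements on the series, on what has been measured and on what is new or still open speak of the compounds shown alone.

Compound 1 `CC(C)CSc1n[nH]c(-n2[se]c3ccccc3c2=O)n1` belongs to a small set of three close relatives. In a functional assay on A549 cells (Homo sapiens) for antiproliferative activity, read by CCK-8 assay, with a stated time of 48 h (a higher number here means a weaker inhibitor, a lower number a stronger inhibitor), compound 1 gives 37800 nM; compound 2 `O=c1c2ccccc2[se]n1-c1nc(SCc2ccc(Cl)cc2)n[nH]1` gives 42100 nM and compound 3 `O=c1c2ccccc2[se]n1-c1nc(SCc2ccc(F)cc2)n[nH]1` gives 36400 nM. All three numbers sit within the usual scatter of one another, as the steps show: a 1.0-fold lower number from compound 1 to compound 3 (0.02 log units; within the scatter) and a 1.1-fold higher number from compound 1 to compound 2 (0.05 log units; within the scatter). Compound 4 `Cc1ccccc1CSc1n[nH]c(-n2[se]c3ccccc3c2=O)n1` differs from compound 1 in one place: 2-methylphenyl in place of isopropyl on a saturated chain carbon bound to a sulfur. Within the data shown here, two measured steps bear on this kind of change, each putting an aromatic ring in place of isopropyl at the same position, and they were a 1.1-fold higher number from compound 1 to compound 2 (0.05 log units; within the scatter) and a 1.0-fold lower number from compound 1 to compound 3 (0.02 log units; within the scatter). On that basis no step beyond the scatter is expected. Compound 4 is therefore estimated to give 38000 nM, with a range from 19000 nM to 76000 nM, a step of a 1.0-fold higher number from compound 1 to compound 4 (0.00 log units; within the scatter).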

Compound 4, half-maximal inhibitory concentration: 9720 nM
For compound 4 the middle estimate is 3.9-fold (0.59 log units) above the measured one, and the stated range ends above it.
By their numbers in this assay, from the lowest: compound 4; then compounds 3, 1 and 2 (each within the scatter of the next).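

In this assay this place on a saturated chain carbon bound to a sulfur proves sensitive to the group it carries: 2-methylphenyl in place of isopropyl gives a 3.9-fold lower number from compound 1 to compound 4 (0.59 log units; beyond the scatter) and also stands apart from the two halogen-bearing rings, with a 3.7-fold lower number from compound 3 to compound 4 (0.57 log units; beyond the scatter) and a 4.3-fold lower number from compound 2 to compound 4 (0.64 log units; beyond the scatter) as the steps. An aromatic ring alone therefore does not set the number, since only compound 4 moves beyond the scatter from compound 1. Nothing at hand explains this step. Whether the methyl group or its place on the ring matters stays open, as the compounds shown include neither plain phenyl nor 4-methylphenyl. Going by these compounds, how a longer chain would behave here also remains unknown.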